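Turning One Double Bond: Compound 2 and Compound 3

The source may hold more compounds than are shown below. What is called first, only, known or untested is meant among the compounds shown, and "the series" means these compounds.

Measured in a functional assay on MDA-MB-468 cells (Homo sapiens) for antiproliferative activity, read by sulforhodamine B assay, with a stated time of 72 h; on this read-out lower numbers stand for stronger inhibition and higher numbers for weaker inhibition:
- Compound 1 `COc1ccc2nc(Cl)c(/C=C\c3ccc(F)cc3)cc2c1`: 15200 nM
- Compound 2 `FC(F)(F)c1cccc(/C=C\c2cc3ccccc3nc2Cl)c1`: 3700 nM

Of these two compounds, compound 2 has the lowest number, and its gap to compound 1 lies beyond the usual scatter of repeated measurements. That makes compound 2, at 3700 nM, the stronger inhibitor of the pair.

The next compound to be tested is compound 3 `FC(F)(F)c1cccc(/C=C/c2cc3ccccc3nc2Cl)c1`. Its relation to compound 2 is simple: the two compounds have the same atoms and bonds and differ only in configuration as drawn: 1 of 1 stereo elements differ; a double bond is drawn Z in compound 2 and E in compound 3. A double bond is drawn Z in compound 2 and E in compound 3.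

For the measured compounds named here, compound 1 and compound 2 are both drawn Z, so the data contain no measured pair showing what this change does in this assay. The expectation is therefore only a cautious one, and a result within the scatter would not be surprising. A modest loss of inhibition is expected, with an estimated step of a 2.2-fold higher number from compound 2 to compound 3 (0.33 log units; beyond the scatter), toward a higher number. For compound 3 the estimated value is 8000 nM, with an expected range from 2500 nM to 30000 nM.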

Compound 3, half-maximal inhibitory concentration: 24000 nM
The estimate for compound 3 lay 3.0-fold (0.48 log units) below the measured number; measured number inside the range.
By their numbers in this assay, from the lowest: compound 2; then compounds 1 and 3 (each within the scatter of the next).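

In this assay, for the compounds shown here, the configuration of the double bond is the first change that can be read as a single step, and it is not a silent one: the step is a 6.5-fold higher number from compound 2 to compound 3 (0.81 log units; beyond the scatter). Compounds 1 and 2 differ in more than one place, so they could not tie a change in the number to any single feature, and both are drawn Z, so they said nothing about the E form. This pair now shows that, on this shared core with the trifluoromethyl group, the Z form gives the lower number, and the step can be laid to the configuration alone because nothing else separates the two compounds: the fact that compounds 2 and 3 differ only in the configuration as drawn

One pair on one core cannot say whether the Z form keeps this advantage with other substituents, and compound 1 has no E partner among the compounds shown. Also open, as far as these compounds go, is how either form would respond to an amine or a carboxylic acid in place of the trifluoromethyl group, and why the configuration matters at all.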